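A few compounds are considered here, and "the series" means these few. Any claim that something is new, unique, unknown or untested is made for them only; others in the source may bear on it.

Measured so far: compound 3 `CCCCNC1=NC2CC(C)C(O)C(O)C2O1` gives 140000 nM; compound 2 `CCCCNC1CC(C)C(O)C(O)C1O` gives 920 nM; compound 1 `CCNC1CC(C)C(O)C(O)C1O` gives 21000 nM.

In an assay on isolated protein (Bos taurus) for inhibition of tissue alpha-L-fucosidase (Homo sapiens) (on this read-out higher numbers stand for weaker inhibition and lower numbers for stronger inhibition), compound 3 stands highest of the three numbers, separated from compound 1 by a margin beyond the scatter and from compound 2 by a still wider one. Compound 4 `CC1CC2N=C(Nc3ccccc3)OC2C(O)C1O` differs from compound 3 by phenyl in place of butyl on an amine nitrogen, so the change sits on the amine nitrogen of the shared bicyclic core, where the open cores of compounds 1 and 2 carry their chains. Going by the values given here, the only measured step on that nitrogen is a 23-fold lower number from compound 1 to compound 2 (1.36 log units; beyond the scatter), a step in chain length rather than a swap of chain for aromatic ring, and made on the open core rather than the fused one. Among the compounds with values here, no measured pair therefore speaks directly to a phenyl group, and the fused core of compound 3 has no second measured partner. The expectation for compound 4 is accordingly held loosely: a step of a 1.4-fold lower number from compound 3 to compound 4 (0.15 log units; within the scatter) is expected in this assay, with the number kept near that of compound 3 and the range set wide to cover movement in either direction. Compound 4 is estimated at 100000 nM, between 20000 nM and 500000 nM.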

Compound 4, half-maximal inhibitory concentration: 7600 nM
Beside the measured number, compound 4's estimate is 13-fold (1.12 log units) above it; the measured number lies below the stated range.
By their numbers in this assay, from the lowest: compound 2; then compound 4; then compound 1; then compound 3.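

In this assay, the amine nitrogen of the core shared by compound 3 and compound 4 proves sensitive to what it carries: phenyl in place of butyl gives an 18-fold lower number from compound 3 to compound 4 (1.27 log units; beyond the scatter). Going by these compounds alone, the only earlier step involving a chain on an amine nitrogen, a 23-fold lower number from compound 1 to compound 2 (1.36 log units; beyond the scatter), came from a change in chain length on the other core, whereas the new step shows that a change of similar size can occur on this core when a chain gives way to a six-membered aromatic ring of carbon only. Nothing measured here accounts for the size of this step, so the result stands as an observation without an explanation.

The compounds shown leave open whether the step belongs to the aromatic ring itself or to any ring of that size, which cyclohexyl on the same nitrogen could test, and whether benzyl or a phenyl carrying chlorine or a methoxy group would move the number further. Within the data shown here, they also leave open whether phenyl would shift the number in the same way on the core of compound 1 and compound 2, as each core offers only a single pair here.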